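The compounds below may be only part of what the source reports. "The series", "measured", "known", "first", "only" and "open" are said of these compounds alone.

Compound 2 `CC(C)Cn1nc(-c2cccs2)c(O)c(C2=NS(=O)(=O)c3cc(NS(C)(=O)=O)ccc3N2)c1=O` is the starting point for this step. In an in vitro ADME assay on microsomes from liver (Homo sapiens) for metabolic stability, tested at 5 uM (a lower number here means that the compound disappears faster, a higher number that the compound lasts longer), compound 2 gives > 1 h, which is a limit of the assay rather than a number. Compound 1 `CS(=O)(=O)Nc1ccc2c(c1)S(=O)(=O)N=C(c1c(O)c(-c3cccs3)nn(CC3CCC3)c1=O)N2` shares the same core with it. In this assay compound 1 gives > 1 h, again a limit and not a number. For the measured compounds named here, the single step joining these two, a step that the two limits leave unreadable from compound 1 to compound 2, therefore cannot be read as a size in either direction. What the measured values do show is summed up as the limit of > 1 h in this assay, at which 2 of the 2 values shown sit.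

Compound 3 `CS(=O)(=O)Nc1ccc2c(c1)S(=O)(=O)N=C(c1c(O)c(-c3cccs3)nn(Cc3ccccn3)c1=O)N2` has not yet been measured. It differs from compound 2 in one place: pyridin-2-yl in place of isopropyl on a saturated chain carbon bound to an aromatic nitrogen. Going by the values given here, no measured step bears directly on a change of this kind, and the only step available is unreadable, so there is no ground for expecting a move in one direction or the other. The expected step that the limit leaves unreadable from compound 2 to compound 3 is thus one of no readable size beyond the scatter. Compound 3 is estimated to give 1.2 h in this assay, with a range from 0.5 h to 3 h, and a real chance that once more only a limit is reported.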

Compound 3, half-life: > 1 h
Compound 3: a limit, no number; the forecaster's own chance of this, stated with the estimate: 55%; the middle value lies beyond the limit too.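

No size can be read for the steps joining compound 1, compound 2 and compound 3, as each of the three gives only a limit of the assay, not a number: the limit of > 1 h in this assay, at which 3 of the 3 values shown sit. As far as these compounds go, how long each compound actually lasts, and whether cyclobutyl, isopropyl or pyridin-2-yl on the saturated chain carbon changes its half-life at all, stays open.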